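Series notes: methylsulfonyl for bromo on the shared core

A few compounds are considered here, and "the series" means these few. Any claim that something is new, unique, unknown or untested is made for them only; others in the source may bear on it.

Compound 1 `O=C(O)c1cccc(C2=C(c3cc(Br)ccc3OCc3ccccc3)CCC2)c1` is characterised in an assay on isolated protein for inhibition of prostaglandin E2 receptor EP3 subtype (Homo sapiens) (on this read-out lower numbers stand for stronger inhibition and higher numbers for weaker inhibition), only by a limit: in this assay compound 1 gives < 3170 nM, which is a limit of the assay and not a number. Compound 2 `CSc1ccc(OCc2ccc(F)cc2)c(C2=C(c3cccc(C(=O)O)c3)CCC2)c1` likewise gives < 3170 nM in this assay, again a limit. Among the compounds with values here, both values sit at the limit of < 3170 nM in this assay, at which 2 of the 2 values shown sit, so no step between measured compounds can be sized. Compound 3 `CS(=O)(=O)c1ccc(OCc2ccccc2)c(C2=C(c3cccc(C(=O)O)c3)CCC2)c1` is not yet measured; it differs from compound 1 by methylsulfonyl in place of bromo on an aromatic carbon. With only limits shown, no direction beyond the scatter can be claimed for this assay. Compound 3 is expected to give 600 nM, spanning 60 nM to 3170 nM, an estimated step that the limit leaves unreadable from compound 1 to compound 3.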

Compound 3, half-maximal inhibitory concentration: < 3170 nM
Compound 3 ended at the assay's limit; the forecaster's own chance of this, stated with the estimate: 45%; the middle value does not contradict the limit.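

In this assay, within the data shown here, no step from compound 1 to compound 3 can be read, as both values are limits: the limit of < 3170 nM in this assay, at which 3 of the 3 values shown sit.

The compounds shown leave open how methylsulfonyl and bromo compare on the shared core.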